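A few compounds are considered here, and "the series" means these few. Any claim that something is new, unique, unknown or untested is made for them only; others in the source may bear on it.

Measured so far in an ADME assay on L02 cells (Homo sapiens) for antiproliferative activity, read by MTT assay, with a stated time of 48 h; a lower number here means a stronger inhibitor, a higher number a weaker inhibitor:
compound 1 `Cc1cccc(-n2nncc2CN2C(=O)C3(C(C#N)=C(N)Oc4c3c3nc5ccccc5nc3c3ccccc43)c3ccccc32)c1` — > 50000 nM
compound 2 `N#CC1=C(N)Oc2c(c3nc4ccccc4nc3c3ccccc23)C12C(=O)N(Cc1cnnn1-c1ccccc1Br)c1ccccc12` — > 50000 nM
compound 3 `N#CC1=C(N)Oc2c(c3nc4ccccc4nc3c3ccccc23)C12C(=O)N(Cc1cnnn1-c1cccc(Br)c1)c1ccccc12` — > 50000 nM

Each of these readings is a limit of this assay rather than a number. For compound 1 the value > 50000 nM is such a limit. For compound 2 the value > 50000 nM is a limit too, so compound 2 stands at the edge of what this assay can report, and the other two stand there with it, as the limit of > 50000 nM in this assay, at which 3 of the 3 values shown sit, shows.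

The step considered here goes from compound 2 to compound 4 `Cc1ccc(-n2nncc2CN2C(=O)C3(C(C#N)=C(N)Oc4c3c3nc5ccccc5nc3c3ccccc43)c3ccccc32)cc1Cl`. 3-chloro-4-methylphenyl in place of 2-bromophenyl on an aromatic nitrogen

For the measured compounds named here, three measured steps concern the same aromatic nitrogen: a step that the two limits leave unreadable from compound 1 to compound 2, a step that the two limits leave unreadable from compound 1 to compound 3 and a step that the two limits leave unreadable from compound 2 to compound 3. None of them has a readable size because all three values sit at the limit of > 50000 nM in this assay, at which 3 of the 3 values shown sit. No step beyond the scatter can therefore be expected in this assay; the expected step is a number no higher from compound 2 to compound 4 (the limit leaves the size open), in no particular direction. Compound 4 is estimated to give 50000 nM, with an expected range from 20000 nM to 120000 nM, most likely again reported as a limit.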

Compound 4, half-maximal inhibitory concentration: > 50000 nM
Compound 4 ended at the assay's limit; the forecaster's own chance of this, stated with the estimate: 80%; the middle value sits exactly at the limit.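

Compound 4 gives > 50000 nM in this assay, which is a limit and not a number, so no step between it and compound 1, compound 2 or compound 3 can be read: the limit of > 50000 nM in this assay, at which 4 of the 4 values shown sit.

The compounds shown leave open how these four truly compare in this assay.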